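The source may report more compounds than this note shows. Statements on the series, on what has been measured and on what is new or still open speak of the compounds shown alone.

Working notes on the series. The shared core of compound 1 `CC1(C)CCCN(CC2(O)CCN(CCCc3c[nH]c4ccc(-n5cnnc5)cc34)CC2)C1` carries a basic side chain; in a functional assay on CHO cells for agonist activity at 5-hydroxytryptamine receptor 1D (Homo sapiens), read by GTPgammaS binding (on this read-out lower numbers stand for an effect already at smaller amounts and higher numbers for an effect only at larger amounts of compound), compound 1 gives 0.9 nM. Compound 2 `CN(CC(C)(C)C)CC1(O)CCN(CCCc2c[nH]c3ccc(-n4cnnc4)cc23)CC1` gives 1.6 nM and compound 3 `CN(CC1CCCCC1)CC1(O)CCN(CCCc2c[nH]c3ccc(-n4cnnc4)cc23)CC1` gives 1.4 nM, so compound 3 sits within the scatter of both others: a 1.6-fold higher number from compound 1 to compound 3 (0.19 log units; within the scatter) and a 1.1-fold lower number from compound 2 to compound 3 (0.06 log units; within the scatter). Compound 4 `OC1(CNCc2ccccc2)CCN(CCCc2c[nH]c3ccc(-n4cnnc4)cc23)CC1` differs from compound 3 by benzylamino in place of (cyclohexylmethyl)(methyl)amino on a saturated chain carbon bound to a saturated ring carbon. The three steps seen so far all touch this same amine position and all stayed within the scatter, so the step to compound 4 is expected to be small as well, a 1.4-fold higher number from compound 3 to compound 4 (0.15 log units; within the scatter), with no direction beyond the scatter. Compound 4 is therefore estimated at 2 nM, range 0.7 nM to 6 nM.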

Compound 4, concentration for half-maximal effect: 2.2 nM
The estimate for compound 4 lay 1.1-fold (0.04 log units) below the measured number, within the range that was stated.
By their numbers in this assay, from the lowest: compounds 1, 3, 2 and 4 (each within the scatter of the next, the first and the last beyond it).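

In this assay this amine position gives its first step beyond the scatter, a modest one: a 2.4-fold higher number from compound 1 to compound 4 (0.39 log units; beyond the scatter), with benzylamino in place of 3,3-dimethylpiperidin-1-yl. The other two steps stay within the scatter, a 1.6-fold higher number from compound 3 to compound 4 (0.20 log units; within the scatter) and a 1.4-fold higher number from compound 2 to compound 4 (0.14 log units; within the scatter), so benzylamino, with its aromatic ring and hydrogen-bond donor, cannot be told apart from either open-chain amine. No available measurement bears on the reason for these steps.

As far as these compounds go, whether the aromatic ring or the amine hydrogen goes with the larger step stays open. Benzyl(methyl)amino or (cyclohexylmethyl)amino at this place would separate the two.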